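Halogen shift on the benzyl group: compound 2 to compound 3

The compounds below may be only part of what the source reports. "The series", "measured", "known", "first", "only" and "open" are said of these compounds alone.

Measured compounds:
compound 1 `Cc1cc(Nc2nc(NCc3cccc(F)c3)nc3[nH]ncc23)n[nH]1`, 458 nM in an assay on isolated protein for inhibition of serine/threonine-protein kinase PAK 4 (Homo sapiens), read by HTRF, with a stated time of 60 min; a higher number here means a weaker inhibitor, a lower number a stronger inhibitor
compound 2 `Cc1cc(Nc2nc(NCc3cccc(Br)c3)nc3[nH]ncc23)n[nH]1`, 4340 nM in this assay

Compound 2 stands as the higher of the two numbers in this assay; its nearest neighbour is compound 1, and the step of a 9.5-fold higher number from compound 1 to compound 2 (0.98 log units; beyond the scatter) sets compound 2 well apart from it. Compound 3 `Cc1cc(Nc2nc(NCc3ccc(Cl)cc3)nc3[nH]ncc23)n[nH]1` has not yet been measured in this assay. It differs from compound 2 in one place: 4-chlorophenyl in place of 3-bromophenyl on a saturated chain carbon bound to a nitrogen on an aromatic ring. So both the halogen and its position on the benzyl ring change at once.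

Going by the values given here, only one measured step bears on this change, and only in part. The step of a 9.5-fold higher number from compound 1 to compound 2 (0.98 log units; beyond the scatter) shows that exchanging the halogen on the 3-position of the benzyl ring moved the number well beyond the scatter. Nothing in the measured compounds speaks to the 4-position. Because the step of a 9.5-fold higher number from compound 1 to compound 2 (0.98 log units; beyond the scatter) runs upward from fluoro to bromo and the change to compound 3 returns to a lighter halogen while also moving it, compound 3 is expected to land between the two measured compounds, with a downward step a 2.9-fold lower number from compound 2 to compound 3 (0.46 log units; beyond the scatter) that may or may not clear the scatter. Compound 3 is estimated at 1500 nM in this assay, within the range 350 nM to 6500 nM.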

Compound 3, half-maximal inhibitory concentration: 515 nM
Beside the measured number, compound 3's estimate is 2.9-fold (0.46 log units) above it, within the range that was stated.
By their numbers in this assay, from the lowest: compounds 1 and 3 (each within the scatter of the next); then compound 2.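

In this assay, replacing the 3-bromophenyl group with 4-chlorophenyl on the saturated chain carbon gives an 8.4-fold lower number from compound 2 to compound 3 (0.93 log units; beyond the scatter), so the high number of compound 2 is not shared by every halogen-bearing phenyl group in this set. Set against the 3-fluorophenyl group, the same 4-chlorophenyl group gives a 1.1-fold higher number from compound 1 to compound 3 (0.05 log units; within the scatter), so these two groups cannot be told apart here, and of the three compounds only the one carrying 3-bromophenyl stands apart. Nothing at hand gives a cause for either step.

The halogen and its place on the ring change together in the step to compound 3, so the compounds shown leave open which of the two changes accounts for it, a question that 3-chlorophenyl and 4-bromophenyl groups on the same carbon would address. Also open, from the compounds shown here alone, is where a phenyl ring bearing a methoxy group, an amine or a carboxylic acid instead of a halogen, or a longer chain in place of the single carbon, would fall relative to these three compounds.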